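The source may hold more compounds than are shown below. What is called first, only, known or untested is meant among the compounds shown, and "the series" means these compounds.

In an ADME assay on MT4 cells (Homo sapiens) for cytotoxicity, read by MTT assay, with a stated time of 5 days (on this read-out higher numbers stand for lower toxicity in this test and lower numbers for higher toxicity in this test), compound 1 `COc1cc2nc([S+]([O-])CC(=O)Nc3ccc([N+](=O)[O-])cc3)nc(Nc3c(Cl)cc(/C=C/C#N)cc3Cl)c2cc1OC` gives 92800 nM. Compound 2 `COc1cc2nc([S+]([O-])CC(=O)Nc3cc([N+](=O)[O-])ccc3F)nc(Nc3c(Cl)cc(/C=C/C#N)cc3Cl)c2cc1OC` reads > 194000 nM, which is a limit of the assay and not a number. Compound 3 `COc1cc2nc([S+]([O-])CC(=O)Nc3ccc(C)cc3)nc(Nc3c(Cl)cc(/C=C/C#N)cc3Cl)c2cc1OC` has 4-methylphenyl in place of 2-fluoro-5-nitrophenyl on an amide-type nitrogen. Within the data shown here, only one measured step involves a swap at this nitrogen: an at least 2.0-fold higher number from compound 1 to compound 2 (0.32 log units; beyond the scatter). That step is modest and rests on (the limit of > 194000 nM in this assay, at which 1 of the 2 values shown sits). With compound 3 resembling compound 1 in carrying a 4-substituted phenyl, a modest move toward lower numbers is expected, namely an at least 1.9-fold lower number from compound 2 to compound 3 (0.28 log units; that floor lies within the scatter). For compound 3, the estimated value is 100000 nM, within an expected range of 35000 nM to 220000 nM.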

Compound 3, half-maximal cytotoxic concentration: 32200 nM
For compound 3 the middle estimate is 3.1-fold (0.49 log units) above the measured one; the measured number lies below the stated range.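

In this assay, methyl in place of nitro on an aromatic carbon gives a 2.9-fold lower number from compound 1 to compound 3 (0.46 log units; beyond the scatter), showing that this one group on the ring changes the number when all else stays the same. The full swap on the amide-type nitrogen gives an at least 6.0-fold lower number from compound 2 to compound 3 (0.77 log units; beyond the scatter). Compound 2 carries a limit of the assay and not a number: the limit of > 194000 nM in this assay, at which 1 of the 3 values shown sits.

The compounds shown leave open whether the lower number comes from gaining methyl or from losing nitro. Going by these compounds, how an amine or a carboxylic acid on that aromatic carbon would read also remains open.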